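A few compounds are considered here, and "the series" means these few. Any claim that something is new, unique, unknown or untested is made for them only; others in the source may bear on it.

Compound 1 `COc1ccccc1NC(=O)N[C@@H]1C2CCN(CC2)[C@@H]1Cc1cccnc1` gives > 10000 nM in an assay on a protein complex for binding affinity to Neuronal acetylcholine receptor; alpha4/beta2 (Homo sapiens) (on this read-out lower numbers stand for stronger inhibition and higher numbers for weaker inhibition), which is a limit of the assay and not a number.
Compound 2 `COc1cccc(NC(=O)N[C@@H]2C3CCN(CC3)[C@@H]2Cc2cccnc2)c1` gives > 10000 nM in this assay, again a limit.
Compound 3 `COc1ccc(NC(=O)N[C@@H]2C3CCN(CC3)[C@@H]2Cc2cccnc2)c(OC)c1` gives > 10000 nM in this assay, also a limit.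

Compound 2 therefore stands only at a limit in this assay, and the two other values shown are limits as well. Compound 4 `O=C(Nc1ccc(F)cc1)N[C@@H]1C2CCN(CC2)[C@@H]1Cc1cccnc1` differs from it by 4-fluorophenyl in place of 3-methoxyphenyl on an amide-type nitrogen. The measured steps that bear on this change are a step that the two limits leave unreadable from compound 1 to compound 2 and a step that the two limits leave unreadable from compound 1 to compound 3, both unreadable in size because of the limit of > 10000 nM in this assay, at which 3 of the 3 values shown sit. Nothing measured here shows any change within the phenyl group moving a compound away from that limit, so the step into compound 4 is expected to be small or absent, and compound 4 is expected to sit at the limit again. The step from compound 2 to compound 4 is estimated as a step that the limit leaves unreadable from compound 2 to compound 4. Compound 4 is expected at 15000 nM, with a range from 3000 nM to 100000 nM.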

Compound 4, inhibition constant: > 10000 nM
Compound 4 ended at the assay's limit (the forecaster's own chance of this, stated with the estimate: 80%); the middle value lies beyond the limit too.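

Compound 4 shows a limit again, so no step among compound 1, compound 2, compound 3 and compound 4 can be read, their sizes remaining unreadable: the limit of > 10000 nM in this assay, at which 4 of the 4 values shown sit.

The compounds shown leave open which change to the shared core would bring a value inside the range of this assay.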